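Methyl to Chloro Swap in a Cytotoxicity Screen

A few compounds are considered here, and "the series" means these few. Any claim that something is new, unique, unknown or untested is made for them only; others in the source may bear on it.

The study compares four compounds in a toxicity assay on NIH3T3 cells (Mus musculus) for cytotoxicity, read by resazurin assay; on this read-out lower numbers stand for an effect already at smaller amounts and higher numbers for an effect only at larger amounts of compound. Compound 1 `COC(=O)c1ccc(NCc2cncn2Cc2cccc(C)c2)cc1-c1ccccc1` and compound 2 `COC(=O)c1ccc(NCc2cncn2Cc2cccc(Cl)c2)cc1-c1ccccc1` share one core, while compound 3 `Cc1ccc(Cn2cncc2CNc2cccc(-c3ccccc3)c2)cc1` and compound 4 `Clc1ccc(Cn2cncc2CNc2cccc(-c3ccccc3)c2)cc1` share another. The difference between the two cores is not broken down here.

In this assay compound 1 gives > 10000 nM, which is a limit of the assay and not a number. Compound 2 gives > 10000 nM, likewise a limit rather than a number. The change between them, (chloro in place of methyl on an aromatic carbon), therefore made a step that the two limits leave unreadable from compound 1 to compound 2. Among the measured compounds shown here, compound 3 is the only compound with a number in this assay, giving 10000 nM.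

Compound 4 has not yet been measured. It differs from compound 3 by chloro in place of methyl on an aromatic carbon. For the measured compounds named here, this is the same kind of change as the one from compound 1 to compound 2, but the place differs: in compound 2 the chloro sits meta to a large group, in compound 4 para to a large group. Two of the three measured values sit at the limit of > 10000 nM in this assay, at which 2 of the 3 values shown sit, so the earlier step offers no readable size to carry over. The expected step is no change at the digits printed from compound 3 to compound 4 (within the scatter), resting on the step that the two limits leave unreadable from compound 1 to compound 2 having shown no readable shift. Compound 4 is accordingly expected to give about 10000 nM, between 5000 nM and 20000 nM, with a fair chance that the assay again reports only a limit.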

Compound 4, half-maximal effective concentration: 10000 nM
Estimate against measurement, compound 4: no gap at the digits printed, and the stated range covers the measured number.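

In this assay, chloro in place of methyl on an aromatic carbon gave no change at the digits printed from compound 3 to compound 4 (within the scatter), so within the core of compound 3 the change from 4-methylbenzyl to 4-chlorobenzyl, para to a large group, had no readable effect on the read-out. The same kind of change in the other core, from compound 1 to compound 2, cannot be read, which leaves no size to set beside the new step and no ground for saying that the two cores agree: the limit of > 10000 nM in this assay, at which 2 of the 4 values shown sit. The series therefore shows one step within the scatter in one core, and it does not show that this change carries from one core to the other.

The compounds shown leave open how this assay would respond to a group of another kind on the same aromatic carbon, such as an amine, a carboxylic acid or a longer chain in place of the methyl. Also open, on these data alone, is what the difference between the two cores does on its own, as compound 1 and compound 3 differ in more than one place.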